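Removing One Sulfamoyl Group from a Silicon-Linked Bis-Sulfamate

This account rests on a few compounds, and the source may have more. Where it says the series, first, only, none or still open, it means among the compounds named here.

Of the compounds shown here, three have been measured in an assay on MCF7 cells for inhibition of Steryl-sulfatase (Homo sapiens), read by scintillation counting, with a stated time of 5 h, tested at 1 uM; a lower number here means a weaker effect, a higher number a stronger effect of the compound at the concentration tested. Compound 1 `CCCC(CCC)(c1ccc(OS(N)(=O)=O)c(C)c1)c1ccc(OS(N)(=O)=O)c(C)c1` holds two propyl chains on its central carbon, and in this assay compound 1 gives 21.1%. Compound 2 `CCC(CC)(c1ccc(OS(N)(=O)=O)cc1)c1ccc(OS(N)(=O)=O)cc1` carries ethyl chains instead, and in this assay compound 2 gives 29.9%. Compound 3 `C[Si](C)(c1ccc(OS(N)(=O)=O)cc1)c1ccc(OS(N)(=O)=O)cc1` has a dimethylsilicon atom at its centre, and in this assay compound 3 gives 81.9%. That is the highest of the three numbers; the gap to compound 2 and the larger gap to compound 1 both lie beyond the usual scatter, so on these figures compound 3 is the most active of the three.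

Compound 4 `C[Si](C)(c1ccc(O)cc1)c1ccc(OS(N)(=O)=O)cc1` keeps the silicon centre and differs from compound 3 in one place: hydrogen in place of sulfamoyl on an oxygen on an aromatic ring. For the measured compounds named here, every measured compound carries two sulfamoyl groups, and compound 4 would be the first with only one, so no measured pair shows what this change does. The expectation rests on the change alone, and the step of a number 31.9 percentage points lower from compound 3 to compound 4 (beyond the scatter) is estimated to be downward and beyond the scatter. In this assay compound 4 is expected to reach about 50%, within a range from 20% to 78%.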

Compound 4, a percentage reported as inhibition, at one concentration (the size of the read-out at that concentration, not a potency): 76.4%
The estimate for compound 4 lay 26.4 percentage points below the measured number; low and high end bracket the measured number.
By their numbers in this assay, from the lowest: compounds 1 and 2 (each within the scatter of the next); then compounds 4 and 3 (each within the scatter of the next).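

In this assay, exchanging sulfamoyl for hydrogen on an oxygen on an aromatic ring, which turns a sulfamoyloxy group into a hydroxy group, gives a number 5.5 percentage points lower from compound 3 to compound 4 (within the scatter). For the compounds shown here, all the earlier compounds carried two sulfamoyl groups, and this pair shows that, with the silicon centre in place, the read-out at this single concentration cannot be told apart whether one sulfamoyl group or two are present. No independent evidence here bears on why the two compounds read alike.

Because this is a read-out at one concentration and not a potency, the pair leaves open whether compound 3 and compound 4 would also match across a range of concentrations, and whether the same exchange would be as well tolerated on the carbon-centred compounds 1 and 2. It also leaves open what a methoxy group or an amine would do on that ring position in place of the hydroxy group, and whether the sulfamoyl group that remains in compound 4 can be exchanged in the same way.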